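Working notes: methyl for methylsulfonyl in compound 4

This account rests on a few compounds, and the source may have more. Where it says the series, first, only, none or still open, it means among the compounds named here.

Measured in a functional assay on Raji cells (Homo sapiens) for antiproliferative activity, read by CCK-8 assay, with a stated time of 48 h; a lower number here means a stronger inhibitor, a higher number a weaker inhibitor:
- compound 1 `C=CC(=O)Nc1cccc(-n2cnc3cnc(Nc4ccc(N5CCN(C)CC5)cc4)nc32)c1`: 7550 nM
- compound 2 `C=CC(=O)Nc1cccc(-n2cnc3cnc(Nc4ccc(N5CCN(CC)CC5)cc4OC)nc32)c1`: > 40000 nM (a limit, not a number)
- compound 3 `C=CC(=O)Nc1cccc(-n2cnc3cnc(Nc4ccc(N5CCN(S(C)(=O)=O)CC5)cc4OC)nc32)c1`: 21900 nM

Not yet measured: compound 4 `C=CC(=O)Nc1cccc(-n2cnc3cnc(Nc4ccc(N5CCN(C)CC5)cc4OC)nc32)c1`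

Compound 3 at 21900 nM holds the higher of the two actual numbers, and compound 1 at 7550 nM lies below it by a gap beyond the scatter. Going on to compound 4, the change is methyl in place of methylsulfonyl on an amine nitrogen in a ring, that is, 4-(methylsulfonyl)piperazin-1-yl to 4-methylpiperazin-1-yl. Among the measured compounds shown here, the only measured step on this nitrogen is an at least 1.8-fold lower number from compound 2 to compound 3 (0.26 log units; that floor lies within the scatter), with methylsulfonyl in place of ethyl. Read backwards, that step hints at a higher number for compound 4, while the 4-methylpiperazin-1-yl group of compound 1 at 7550 nM hints at a lower one. Going by these compounds, no clear step is therefore expected in this assay, and the direction stays open. The expected change is a 1.1-fold lower number from compound 3 to compound 4 (0.04 log units; within the scatter) by this estimate. Compound 4 is estimated at 20000 nM, with an expected range of 8000 nM to 40000 nM for the measurement.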

Compound 4, half-maximal inhibitory concentration: 13700 nM
Compound 4: the middle estimate sits 1.5-fold (0.16 log units) above what was measured; measured number inside the range.
By their numbers in this assay, from the lowest: compounds 1, 4 and 3 (each within the scatter of the next, the first and the last beyond it). At a limit, above all of these: compound 2.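

In this assay, among the compounds shown here, the exchange of 4-(methylsulfonyl)piperazin-1-yl for 4-methylpiperazin-1-yl gives the first step on this amine nitrogen with a real number at both ends, and a 1.6-fold lower number from compound 3 to compound 4 (0.20 log units; within the scatter) shows no clear effect of the change. Methoxy in place of hydrogen on the aromatic carbon, read as a 1.8-fold higher number from compound 1 to compound 4 (0.26 log units; within the scatter), likewise shows no clear effect, so that group and the methyl compound can be read together. The substituent on this nitrogen can still matter, as hydrogen in place of methyl on the saturated chain carbon gives an at least 2.9-fold lower number from compound 2 to compound 4 (0.46 log units; beyond the scatter), but compound 2 stands at a limit, not a number, so that step is only a floor: the limit of > 40000 nM in this assay, at which 1 of the 4 values shown sits.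

Going by these compounds, whether a free hydrogen, an acetyl group or a longer chain ending in a hydroxyl on this nitrogen would move the number beyond the scatter stays open. On these data alone, the ethyl step also rests on one pair, so whether it holds on a core without methoxy is unknown.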